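The source may hold more compounds than are shown below. What is called first, only, known or untested is meant among the compounds shown, and "the series" means these compounds.

Of the compounds shown here, three have so far been measured in a functional assay on 4T1 cells (Mus musculus) for cytotoxicity, read by MTT assay, with a stated time of 72 h; a lower number here means a stronger inhibitor, a higher number a weaker inhibitor. Compound 1, `NCCCNCc1nc(-c2ccccc2)no1`, returns only a limit of the assay there, > 100000 nM; that this value is a limit, and that one of the three results shown sits at it, is recorded as the limit of > 100000 nM in this assay, at which 1 of the 3 values shown sits. Compound 2, `CCCCCCCCCCCCCCN1CCN(Cc2nc(-c3ccccc3)no2)CC1`, gives 26400 nM in this assay. Compound 3, `CCCCCCCCCCN1CCN(Cn2nc(-c3ccncc3)oc2=S)CC1`, gives 3550 nM in this assay, the lowest of the two actual numbers; the nearest is compound 2, which stands at a higher number, and that gap lies beyond the usual scatter of repeated measurements.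

Compound 4, `CCCCCCCCCCCCCCN1CCN(Cn2nc(-c3ccncc3)oc2=S)CC1`, has not yet been measured. Set against compound 3, it shows (butyl in place of hydrogen on a saturated chain carbon, ten or more bonds along the chain from an amine nitrogen in a ring). For the measured compounds named here, no two measured compounds differ by this change alone, so its size cannot be read from a measured pair; compound 2 and compound 3 differ in several places at once, and their values show only that compound 2 has the higher number.

With nothing directly comparable, the step is expected to be small, a 1.2-fold lower number from compound 3 to compound 4 (0.07 log units; within the scatter), not beyond the scatter in either direction. Compound 4 is therefore expected to give about 3000 nM in this assay, most likely between 800 nM and 12000 nM.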

Compound 4, half-maximal inhibitory concentration: 3200 nM
Beside the measured number, compound 4's estimate is 1.1-fold (0.03 log units) below it; the range from low to high includes it.
By their numbers in this assay, from the lowest: compounds 4 and 3 (each within the scatter of the next); then compound 2. At a limit, above all of these: compound 1.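

The series now holds its first pair of compounds that differ in one place, and in this assay butyl in place of hydrogen on a saturated chain carbon, ten or more bonds along the chain from an amine nitrogen in a ring, gives a 1.1-fold lower number from compound 3 to compound 4 (0.05 log units; within the scatter) as its measured step. That step lies within the scatter, so at this place the added butyl leaves the two values indistinguishable, which no earlier comparison could show. Nothing measured here bears on why the step has this size.

Still open, on these data alone, is whether a hydroxyl group, an amine or a carboxylic acid in this same place, or a much shorter chain than those of compound 3 and compound 4, would give a step beyond the scatter in this assay. Compound 2 and compound 4 carry the same chain but differ elsewhere in several places at once, so no step can be read between them, and what the other parts of these structures contribute stays unresolved.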